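Ortho substituent swap: from chloro to nitro on the hydrazone

This account rests on a few compounds, and the source may have more. Where it says the series, first, only, none or still open, it means among the compounds named here.

Measured compounds:
compound 1, `CC1=CC[C@H](C(C)(C)NC(=S)N/N=C/c2ccccc2)CC1`, 9900 nM in a functional assay on 786-0 cells (Homo sapiens) for inhibition, read by sulforhodamine B assay, with a stated time of 48 h; a lower number here means a stronger inhibitor of growth, a higher number a weaker inhibitor of growth
compound 2, `CC1=CC[C@H](C(C)(C)NC(=S)N/N=C/c2ccccc2O)CC1`, 4600 nM in this assay
compound 3, `CC1=CC[C@H](C(C)(C)NC(=S)N/N=C/c2ccccc2Cl)CC1`, 85500 nM in this assay

Of the three, compound 3 gives the highest number in this assay; the step to it from compound 1 was an 8.6-fold higher number from compound 1 to compound 3 (0.94 log units; beyond the scatter), and from compound 2 it was a 19-fold higher number from compound 2 to compound 3 (1.27 log units; beyond the scatter). Compound 4, `CC1=CC[C@H](C(C)(C)NC(=S)N/N=C/c2ccccc2[N+](=O)[O-])CC1`, differs from compound 3 by nitro in place of chloro on an aromatic carbon. Among the measured compounds shown here, no measured step involves a nitro group, so the steps that bear on it only show that replacing the chloro of compound 3 by hydrogen or hydroxy lowered the number. The expectation for compound 4 is therefore a lower number than compound 3, a step of about a 3.4-fold lower number from compound 3 to compound 4 (0.53 log units; beyond the scatter) in this assay, with wide uncertainty. Compound 4 is estimated at 25000 nM, within 5000 nM to 120000 nM.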

Compound 4, concentration for 50% growth inhibition: 68500 nM
Compound 4: the middle estimate sits 2.7-fold (0.44 log units) below what was measured; low and high end bracket the measured number.
By their numbers in this assay, from the lowest: compound 2; then compound 1; then compounds 4 and 3 (each within the scatter of the next).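

Nitro and chloro at this position, ortho to a large group, cannot be told apart in this assay (a 1.2-fold lower number from compound 3 to compound 4 (0.10 log units; within the scatter)). Nitro, like chloro, gives a clearly higher number than hydrogen (a 6.9-fold higher number from compound 1 to compound 4 (0.84 log units; beyond the scatter)) and than hydroxy (a 15-fold higher number from compound 2 to compound 4 (1.17 log units; beyond the scatter)), so among these four compounds only hydrogen and hydroxy keep the number low. Nothing available explains this ranking. As far as these compounds go, whether an amine or a carboxylic acid at this position would group with hydroxy or with chloro and nitro remains open.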